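Nitro in place of fluoro: the step to compound 4

This account rests on a few compounds, and the source may have more. Where it says the series, first, only, none or still open, it means among the compounds named here.

In a functional assay on MCF7 cells (Homo sapiens) for cytotoxicity, read by MTT assay, with a stated time of 96 h (on this read-out higher numbers stand for weaker inhibition and lower numbers for stronger inhibition), compound 3 (`COc1cc(C(=O)c2cn(-c3ccc(N)cc3)cc2-c2ccccc2F)cc(OC)c1OC`) gives 28 nM, the lowest of the three numbers at hand. Compound 2 (`COc1cc(C(=O)c2cn(-c3ccc(C)cc3)cc2-c2ccccc2[N+](=O)[O-])cc(OC)c1OC`) stands at 65 nM and compound 1 (`COc1cc(C(=O)c2cn(-c3cccc(F)c3)cc2-c2ccccc2[N+](=O)[O-])cc(OC)c1OC`) at 190 nM, and both lie beyond the scatter from compound 3. Compound 4 (`COc1cc(C(=O)c2cn(-c3ccc(N)cc3)cc2-c2ccccc2[N+](=O)[O-])cc(OC)c1OC`) departs from compound 3 by one change, nitro in place of fluoro on an aromatic carbon, ortho to a large group: nitro in place of fluoro on an aromatic carbon. Among the measured compounds shown here, no measured pair shows this change directly. For the measured compounds named here, compounds 1 and 2 both carry the nitro, and the only measured step, a 2.9-fold lower number from compound 1 to compound 2 (0.47 log units; beyond the scatter), is modest and lies at the aromatic nitrogen, not at the place that changes here. It bears on the question only indirectly. Among the nitro compounds, compound 2 reaches 65 nM, so a modest rise in the number, or none beyond the scatter, is expected in this assay. The expected step is a 1.6-fold higher number from compound 3 to compound 4 (0.21 log units; within the scatter). Compound 4 is estimated at 45 nM, with an expected range of 12 nM to 150 nM.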

Compound 4, half-maximal inhibitory concentration: 53 nM
The estimate for compound 4 lay 1.2-fold (0.07 log units) below the measured number, and the stated range covers the measured number.
By their numbers in this assay, from the lowest: compounds 3, 4 and 2 (each within the scatter of the next, the first and the last beyond it); then compound 1.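

In this assay, among the compounds shown here, the first direct reading at this position gives a 1.9-fold higher number from compound 3 to compound 4 (0.28 log units; within the scatter), so with 4-aminophenyl on the aromatic nitrogen, the change from 2-fluorophenyl to 2-nitrophenyl stays within the scatter. With the nitro group held in place, amino in place of methyl on the aromatic carbon gives a 1.2-fold lower number from compound 2 to compound 4 (0.09 log units; within the scatter), also within the scatter, while 4-aminophenyl in place of 3-fluorophenyl on the aromatic nitrogen gives a 3.6-fold lower number from compound 1 to compound 4 (0.55 log units; beyond the scatter), a modest step beyond it. Nothing available explains these results in terms of any property of the groups.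

The compounds shown leave open whether the nitro and fluoro groups would also stay within the scatter of each other with 4-methylphenyl or 3-fluorophenyl on the aromatic nitrogen. They also leave open how a nitrile, a methoxy group or an amine would read at this same aromatic carbon.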